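The compounds below may be only part of what the source reports. "The series", "measured", "known", "first", "only" and "open" are said of these compounds alone.

Compound 1 `C#CCN(Cc1ccc2nc(C)nc(O)c2c1)c1ccc(C(=O)N[C@@H](CCC(=O)O)C(=O)N2CCCC2C(=O)O)cc1`: 35 nM. Compound 2 `C#CCN(Cc1ccc2nc(C)nc(O)c2c1)c1ccc(C(=O)N[C@@H](CC(C)(C)C(=O)O)C(=O)N[C@@H](CCC(=O)O)C(=O)O)cc1`: 18 nM.

Both were tested in an assay on L1210 cells for inhibition of Thymidylate synthase (Mus musculus); a lower number here means a stronger inhibitor, a higher number a weaker inhibitor. Compound 1 gives the higher of the two numbers, yet compound 2 lies within the scatter of it, so the two cannot be ranked. Compound 3 `C#CCN(Cc1ccc2nc(C)nc(O)c2c1)c1ccc(C(=O)N[C@@H](CCC(=O)O)C(=O)NC(C)(C)C(=O)O)cc1` differs from compound 1 in one place: (1-carboxy-1-methylethyl)amino in place of 2-carboxypyrrolidin-1-yl on a carbonyl carbon. Among the measured compounds shown here, no measured pair shows what such a change does, so the expectation is cautious: a small step in this assay, probably not beyond the scatter, in either direction. Compound 3 is expected to give 45 nM, within 15 nM to 140 nM. That expectation amounts to a step of a 1.3-fold higher number from compound 1 to compound 3 (0.11 log units; within the scatter).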

Compound 3, inhibition constant: 42 nM
Estimate against measurement, compound 3: 1.1-fold (0.03 log units) above; low and high end bracket the measured number.
By their numbers in this assay, from the lowest: compounds 2, 1 and 3 (each within the scatter of the next, the first and the last beyond it).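

On this carbonyl carbon, (1-carboxy-1-methylethyl)amino in place of 2-carboxypyrrolidin-1-yl gives a 1.2-fold higher number from compound 1 to compound 3 (0.08 log units; within the scatter) in this assay. The five-membered non-aromatic ring can therefore give way to an open chain that still carries a carboxylic acid, and the two compounds cannot be told apart in this assay. No measurement at hand explains this result.

From the compounds shown here alone, it remains open whether the carboxylic acid itself matters here. A simple amide or a methyl ester at this place, or a longer chain carrying the acid, would help to answer that.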